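Sulfonyl Aryl Changes in a Hydroxamic Acid Series

The source may hold more compounds than are shown below. What is called first, only, known or untested is meant among the compounds shown, and "the series" means these compounds.

Measured compounds:
compound 1, `O=C(/C=C/c1cnc(N2CCN(S(=O)(=O)c3ccc4ccccc4c3)CC2)s1)NO`, 700 nM
compound 2, `Cc1ccc(S(=O)(=O)N2CCN(c3ncc(/C=C/C(=O)NO)s3)CC2)cc1`, 2000 nM
compound 3, `O=C(/C=C/c1cnc(N2CCN(S(=O)(=O)c3ccc(-c4ccccc4)cc3)CC2)s1)NO`, 1500 nM

All three share one core and differ only in the group on the sulfonyl sulfur. In a functional assay on MCF7 cells (Homo sapiens) for antiproliferative activity (a lower number here means a stronger inhibitor of growth, a higher number a weaker inhibitor of growth), compound 3 holds the second highest number of the three. Its nearest neighbour is compound 2, and the step of a 1.3-fold lower number from compound 2 to compound 3 (0.12 log units; within the scatter) lies within the scatter. Compound 1 stands furthest away from compound 3, with the lower number of the two, and that gap is beyond the scatter.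

Compound 4 is `O=C(/C=C/c1cnc(N2CCN(S(=O)(=O)c3ccc(C(F)(F)F)cc3)CC2)s1)NO`. It arises from compound 3 by trifluoromethyl in place of phenyl on an aromatic carbon. Among the compounds with values here, two measured steps touch the same place. The step of a 2.9-fold higher number from compound 1 to compound 2 (0.46 log units; beyond the scatter) was a modest rise, beyond the scatter. The step of a 1.3-fold lower number from compound 2 to compound 3 (0.12 log units; within the scatter) stayed within the scatter. Neither step involves a trifluoromethyl group, so the data give no direct measure of it; what they show is that exchanging one group for another on this aromatic carbon moved the number little. Compound 4 is therefore expected to show a step of a 1.1-fold higher number from compound 3 to compound 4 (0.05 log units; within the scatter) in this assay, not beyond the scatter. The estimate for compound 4 is 1700 nM, with a range from 700 nM to 4000 nM.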

Compound 4, concentration for 50% growth inhibition: 3000 nM
For compound 4 the middle estimate is 1.8-fold (0.25 log units) below the measured one; the range from low to high includes it.
By their numbers in this assay, from the lowest: compound 1; then compounds 3, 2 and 4 (each within the scatter of the next).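

In this assay, trifluoromethyl on the aromatic carbon para to a large group gives a 2.0-fold higher number from compound 3 to compound 4 (0.30 log units; within the scatter) when it replaces phenyl and a 1.5-fold higher number from compound 2 to compound 4 (0.18 log units; within the scatter) when it replaces methyl, so compound 4 cannot be told apart from compound 2 or compound 3, and a fluorine-bearing group joins methyl and phenyl without separating from either. Set against the naphthalen-2-yl group on the sulfonyl sulfur, the 4-(trifluoromethyl)phenyl group gives a 4.3-fold higher number from compound 1 to compound 4 (0.63 log units; beyond the scatter) as a modest step, the same kind of separation seen in a 2.9-fold higher number from compound 1 to compound 2 (0.46 log units; beyond the scatter), which leaves compound 1 as the only one of the four whose number stands apart from the rest. Nothing among the data offers an explanation for either of these results.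

On these data alone, it remains open whether an amine or a carboxylic acid on this aromatic carbon would stay within the same band as methyl, phenyl and trifluoromethyl. As far as these compounds go, it is also open whether the separation of compound 1 belongs to the naphthalen-2-yl group in particular, or whether a naphthalen-1-yl or quinoline group on the sulfonyl sulfur would give a similar number.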